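The source may hold more compounds than are shown below. What is called first, only, known or untested is meant among the compounds shown, and "the series" means these compounds.

Measured so far:
- Compound 1 `CCC1=C(O)c2c(oc(-c3cccc(C)c3)cc2=O)C(CC)(CC)C1=O`: 3.69 uM
- Compound 2 `CCC1=C(O)c2c(oc(-c3ccc(C)c(Cl)c3)cc2=O)C(CC)(CC)C1=O`: 2.15 uM

Going by the values given here, in a functional assay on KBVIN cells (Homo sapiens) for antiproliferative activity, read by sulforhodamine B assay, with a stated time of 3 days (a lower number here means that less compound is needed, a higher number that more compound is needed for the effect), compound 2 gives 2.15 uM, level with its only neighbour: the gap is a 1.7-fold lower number from compound 1 to compound 2 (0.23 log units; within the scatter). Compound 3 `CCC1=C(O)c2c(oc(-c3ccc(OC)cc3C)cc2=O)C(CC)(CC)C1=O` is still unmeasured and carries a new group on the same aromatic carbon, 4-methoxy-2-methylphenyl in place of 3-chloro-4-methylphenyl on an aromatic carbon. Among the compounds with values here, the one measured step that bears on this swap is a 1.7-fold lower number from compound 1 to compound 2 (0.23 log units; within the scatter), so no shift beyond the scatter is expected. The expected change is a 1.3-fold higher number from compound 2 to compound 3 (0.11 log units; within the scatter). For compound 3 the estimated value is 2.8 uM, with an expected range of 0.9 uM to 8 uM.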

Compound 3, concentration for half-maximal effect: 2.62 uM
For compound 3 the middle estimate is 1.1-fold (0.03 log units) above the measured one; low and high end bracket the measured number.
By their numbers in this assay, from the lowest: compounds 2, 3 and 1 (each within the scatter of the next).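

In this assay, the position accepts a third aryl group with no shift beyond the scatter: 4-methoxy-2-methylphenyl replaces 3-chloro-4-methylphenyl (a 1.2-fold higher number from compound 2 to compound 3 (0.09 log units; within the scatter)) and also 3-methylphenyl (a 1.4-fold lower number from compound 1 to compound 3 (0.15 log units; within the scatter)). The entering group has oxygen where the leaving one has chlorine, and a hydrogen-bond acceptor where 3-chloro-4-methylphenyl has none, yet the numbers stay level. Nothing here accounts for this. On these data alone, whether an amine or a carboxylic acid on this aryl ring would move the number beyond the scatter stays open, as does how a phenyl ring carrying only a methoxy group would read.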